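This account rests on a few compounds, and the source may have more. Where it says the series, first, only, none or still open, it means among the compounds named here.

Compound 1 `Cc1cc(NC(C)C)nc(SCc2nc3ccccc3[nH]2)n1`: > 100000 nM
Compound 2 `Cc1cc(NNC(N)=S)nc(SCc2nc3ccccc3[nH]2)n1`: > 100000 nM

Both compounds were tested in a functional assay on PC-3 cells (Homo sapiens) for cytotoxicity, read by MTT assay, with a stated time of 72 h; on this read-out lower numbers stand for stronger inhibition and higher numbers for weaker inhibition. In this assay compound 1 gives > 100000 nM, which is a limit of the assay and not a number. In this assay compound 2 likewise gives > 100000 nM, again a limit rather than a number. Compound 2 therefore stands at the edge of what this assay can report, as does the other value shown, since (the limit of > 100000 nM in this assay, at which 2 of the 2 values shown sit). Among the measured compounds shown here, the one measured step, a step that the two limits leave unreadable from compound 1 to compound 2, accordingly cannot be read in size or direction.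

Compound 3 `COc1ccccc1Nc1cc(C)nc(SCc2nc3ccccc3[nH]2)n1` differs from compound 2 in one place: a group of 8 heavy atoms (7 carbon, 1 oxygen; one six-membered aromatic ring of carbon only) in place of a group of 4 heavy atoms (1 carbon, 2 nitrogen, 1 sulfur; no ring), on a nitrogen on an aromatic ring. For the measured compounds named here, no measured step bears on this change, because the only step, a step that the two limits leave unreadable from compound 1 to compound 2, is unreadable. With both measured compounds at the limit, no step beyond the scatter can be expected in either direction, and the most likely outcome is again a limit. Compound 3 is expected at about 80000 nM, with a range from 20000 nM to 300000 nM. This estimate corresponds to an expected step of an at least 1.2-fold lower number from compound 2 to compound 3 (0.09 log units; that floor lies within the scatter).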

Compound 3, half-maximal inhibitory concentration: 70800 nM
For compound 3 the middle estimate is 1.1-fold (0.05 log units) above the measured one, within the range that was stated.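

Among the compounds shown here, with 2-methoxyphenyl on the nitrogen on the aromatic ring, compound 3 gives 70800 nM in this assay, the only value shown so far that is a number and not a limit. Putting 2-methoxyphenyl in place of the ring-free group that carries sulfur gives an at least 1.4-fold lower number from compound 2 to compound 3 (0.14 log units; that floor lies within the scatter), and putting it in place of isopropyl gives an at least 1.4-fold lower number from compound 1 to compound 3 (0.14 log units; that floor lies within the scatter). Each step is only a floor, whose true size cannot be read, since the other compound in each pair stands at a limit of the assay: the limit of > 100000 nM in this assay, at which 2 of the 3 values shown sit.

It remains open whether plain phenyl, without the methoxy group, or benzyl, with one more carbon between the nitrogen and the ring, would also give a number rather than a limit, so the compounds shown do not separate the part played by the ring from that of the methoxy group. As far as these compounds go, it also remains open how a group of another kind at this nitrogen, such as a carboxylic acid on a short chain or a longer unbranched alkyl chain, would read in this assay.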